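The compounds below may be only part of what the source reports. "The series", "measured", "known", "first", "only" and "open" are said of these compounds alone.

Compound 1 `O=[N+]([O-])c1ccc(CSCc2c[nH]cn2)cc1`: > 10 mg/kg (a limit)
Compound 2 `O=[N+]([O-])c1ccc(OCCc2c[nH]cn2)cc1`: 0.66 mg/kg

In a functional assay on the whole organism (brain) with Mus musculus as the target (a higher number here means that more compound is needed for the effect, a lower number that less compound is needed), compound 1 gives > 10 mg/kg, which is a limit of the assay and not a number. Going by the values given here, compound 2, at 0.66 mg/kg, holds the only actual number so far, so it cannot yet be ranked against a second measured value.

The next compound is compound 3 `Cc1ccc(OCCc2c[nH]cn2)cc1`, which has methyl in place of nitro on an aromatic carbon, para to a group of 8 heavy atoms: methyl in place of nitro on an aromatic carbon. Among the compounds with values here, no measured pair shows this exchange, so any expectation is loosely grounded. A moderate shift toward a higher dose is expected, and the estimated step is a 3.0-fold higher number from compound 2 to compound 3 (0.48 log units; beyond the scatter). For compound 3 the estimated value is 2 mg/kg, with an expected range of 0.6 mg/kg to 8 mg/kg.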

Compound 3, dose for half-maximal effect: 2.3 mg/kg
Beside the measured number, compound 3's estimate is 1.2-fold (0.06 log units) below it, within the range that was stated.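

In this assay, going by these compounds alone, the exchange of methyl for nitro on an aromatic carbon, para to a group of 8 heavy atoms, gives the first readable step: a 3.5-fold higher number from compound 2 to compound 3 (0.54 log units; beyond the scatter). This shows that the dose depends on the group at this position, and that the effect survives the loss of nitro, since compound 3 still gives 2.3 mg/kg. Compound 1 stands at a limit of the assay and not at a number, so it adds no readable step: the limit of > 10 mg/kg in this assay, at which 1 of the 3 values shown sits.

From the compounds shown here alone, one exchange at one position gives two points and no trend, so how other groups at this place, such as chloro, methoxy or an amine, would fall relative to nitro and methyl remains open. Also open, going by these compounds, is how a longer chain on the shared core would change the dose needed.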